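The compounds below may be only part of what the source reports. "The series", "measured", "known", "first", "only" and "open" are said of these compounds alone.

Two compounds of a shared core carry the same sulfonyl-morpholine-bearing acyl hydrazone and differ only at the ring on the carbon with a double bond to nitrogen. Compound 1 `O=C(N/N=C/c1ccccn1)c1cccc(S(=O)(=O)N2CCOCC2)c1` bears a pyridin-2-yl there; in a functional assay on PC-3 cells (Homo sapiens) for antiproliferative activity, read by MTT assay, with a stated time of 72 h (a lower number here means a stronger inhibitor, a higher number a weaker inhibitor), compound 1 gives 88100 nM. Compound 2 `O=C(N/N=C/c1ccccc1O)c1cccc(S(=O)(=O)N2CCOCC2)c1` bears a 2-hydroxyphenyl instead, and in this assay compound 2 gives 13800 nM. For the measured compounds named here, that single exchange produced a 6.4-fold lower number from compound 1 to compound 2 (0.81 log units; beyond the scatter), so compound 2 stands as the lower of the two numbers measured so far, with compound 1 as its only neighbour.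

Compound 3 `COc1ccc(/C=N/NC(=O)c2cccc(S(=O)(=O)N3CCOCC3)c2)c(O)c1` is not yet measured. It differs from compound 2 by methoxy in place of hydrogen on an aromatic carbon, placed on an aromatic carbon of a six-membered aromatic ring of carbon only, para to a large group. Going by the values given here, no measured step here shows a methoxy entering in place of hydrogen; the one step available concerns a different ring and cannot be carried over. Compound 3 is therefore expected to give roughly 8000 nM in this assay, within a range of 2500 nM to 30000 nM. This estimate means a 1.7-fold lower number from compound 2 to compound 3 (0.24 log units; within the scatter), a step expected to fall close to the scatter rather than clearly beyond it.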

Compound 3, half-maximal inhibitory concentration: 5800 nM
Compound 3: the middle estimate sits 1.4-fold (0.14 log units) above what was measured; the range from low to high includes it.
By their numbers in this assay, from the lowest: compound 3; then compound 2; then compound 1.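

In this assay the ring on the carbon with a double bond to nitrogen responds to a change of substituent as well as to an exchange of the whole ring: methoxy in place of hydrogen on an aromatic carbon, para to a large group and meta to a hydroxy group, gives a 2.4-fold lower number from compound 2 to compound 3 (0.38 log units; beyond the scatter) and thus a step beyond the scatter from a small addition to the 2-hydroxyphenyl of compound 2. For the compounds shown here, measured against the pyridin-2-yl of compound 1, the 2-hydroxy-4-methoxyphenyl group gives a 15-fold lower number from compound 1 to compound 3 (1.18 log units; beyond the scatter) and this is the only step among the three compounds that counts as large. No accompanying data explain why the number falls with either change.

On these data alone, whether the methoxy step depends on the hydroxy group stays open, as the step is seen here only on the 2-hydroxyphenyl ring. Also open, as far as these compounds go, is how a longer chain such as ethoxy, an amine or a carboxylic acid would behave at this same place on the ring, and whether the number would continue to fall.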